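Phenyl for thiophen-2-yl at the assay limit

The compounds below may be only part of what the source reports. "The series", "measured", "known", "first", "only" and "open" are said of these compounds alone.

In a functional assay on A549 cells (Homo sapiens), read by MTT assay, with a stated time of 72 h (a lower number here means a stronger inhibitor, a higher number a weaker inhibitor), compound 1 (`C#Cc1cn([C@@H]2O[C@H](CO)[C@@H](O)[C@H]2O)c2ncnc(SC)c12`) gives 140 nM. Compound 2 (`Nc1nc(N)c2c(-c3cccs3)cn([C@@H]3O[C@H](CO)[C@@H](O)[C@H]3O)c2n1`) reads > 20000 nM, which is a limit and not a number. Compound 3 (`Cc1nc(N)c2c(-c3cccs3)cn([C@@H]3O[C@H](CO)[C@@H](O)[C@H]3O)c2n1`) reads > 20000 nM, again only a limit. It therefore stands with compound 2 at the limit of > 20000 nM in this assay, at which 2 of the 3 values shown sit.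

Compound 4 (`Cc1nc(N)c2c(-c3ccccc3)cn([C@@H]3O[C@H](CO)[C@@H](O)[C@H]3O)c2n1`) replaces thiophen-2-yl with phenyl on an aromatic carbon, (phenyl in place of thiophen-2-yl on an aromatic carbon). Among the measured compounds shown here, the only measured step that touches compound 3 is a step that the two limits leave unreadable from compound 2 to compound 3. For the measured compounds named here, that step has no readable size and concerns a different change, and no measured step exchanges one aromatic ring for another. No size or direction can be carried over from the measured compounds, so no shift beyond the scatter is expected in this assay. The expectation rests on compound 3, whose > 20000 nM is a limit.

The expected change is a step that the limit leaves unreadable from compound 3 to compound 4. Compound 4 is most likely to be reported only as a limit again, and its estimated value is 30000 nM, with an expected range from 10000 nM to 60000 nM.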

Compound 4, half-maximal inhibitory concentration: > 20000 nM
Compound 4: a limit, no number (the forecaster's own chance of this, stated with the estimate: 85%); the middle value lies beyond the limit too.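

Among the compounds shown here, compound 3 and compound 4 both give only a limit, so no step of readable size can be taken from the exchange of thiophen-2-yl for phenyl. They stand together at the same limit: the limit of > 20000 nM in this assay, at which 3 of the 4 values shown sit.

The compounds shown leave open whether phenyl and thiophen-2-yl differ at all in this assay.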